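A few compounds are considered here, and "the series" means these few. Any claim that something is new, unique, unknown or untested is made for them only; others in the source may bear on it.

In a functional assay on LM7 cells (Homo sapiens) for antiproliferative activity, read by MTT assay, with a stated time of 72 h (a higher number here means a weaker inhibitor, a lower number a stronger inhibitor), compound 1 `CCOC(=O)c1cc(=O)c2cc(CSC(=S)N(C)c3ccccc3)ccc2o1` gives > 25000 nM, which is a limit of the assay rather than a number. Compound 2 `O=c1cc(CSC(=S)N2CCCCC2)oc2ccccc12` likewise gives > 25000 nM, again a limit. Going by the values given here, compound 3 `O=c1c(Cl)c(CSC(=S)N2CCCCC2)oc2ccccc12` gives 3300 nM, the only number among the three values shown. The other two values sit at the limit of > 25000 nM in this assay, at which 2 of the 3 values shown sit. Among the compounds with values here, the single measured step is an at least 7.5-fold lower number from compound 2 to compound 3 (0.87 log units; beyond the scatter), a change at an aromatic carbon. Compound 4 `O=c1c(Cl)c(CSC(=S)N2CCOCC2)oc2ccccc12` differs from compound 3 by morpholin-4-yl in place of piperidin-1-yl on a thiocarbonyl carbon. Within the data shown here, no measured step bears on this change, which sits at a different place from the one step known. Compound 4 is therefore expected to stand near compound 3, with a 1.4-fold higher number from compound 3 to compound 4 (0.13 log units; within the scatter) expected to remain within the scatter. Compound 4 is estimated at 4500 nM, in the range 1500 nM to 15000 nM.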

Compound 4, half-maximal inhibitory concentration: 19200 nM
For compound 4 the middle estimate is 4.3-fold (0.63 log units) below the measured one; measured number above the stated range.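

The group on the thiocarbonyl carbon proved to matter: in this assay morpholin-4-yl in place of piperidin-1-yl gives a 5.8-fold higher number from compound 3 to compound 4 (0.76 log units; beyond the scatter) with the chloro group kept in place. A second ring hetero atom, and with it one hydrogen-bond acceptor, thus goes with the weaker value in this pair. Compound 4 also stands close to the assay's upper limit: the limit of > 25000 nM in this assay, at which 2 of the 4 values shown sit.

From the compounds shown here alone, whether diethylamino or piperazin-1-yl on this carbon would stand nearer compound 3 or compound 4 stays open. So does whether an azepan-1-yl ring would behave like piperidin-1-yl.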